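The compounds below may be only part of what the source reports. "The series", "measured", "known", "first", "only" and "open" are said of these compounds alone.

The measured compounds:
compound 1 `COc1cc(Cl)cc(-c2nn(-c3cccc(NC(=O)Nc4ccc(Cl)c(C(F)(F)F)c4)c3)cc2-c2ccncc2)c1` — in a functional assay on KM12 cells (Homo sapiens) for inhibition, read by sulforhodamine B assay, with a stated time of 48 h, tested at 10 uM (on this read-out higher numbers stand for a weaker effect at the one concentration tested and lower numbers for a stronger effect), compound 1 gives 9.1%
compound 2 `COc1cc(Cl)cc(-c2nn(-c3cccc(NC(=O)c4cccc(C(F)(F)F)c4)c3)cc2-c2ccncc2)c1` — in this assay compound 2 gives 43.7%

Among the compounds with values here, of these two numbers compound 2 stands highest, which on this read-out means the weaker effect; the one measured step, a number 34.6 percentage points higher from compound 1 to compound 2 (beyond the scatter), separates it from compound 1. Compound 3 `COc1cc(Cl)cc(-c2nn(-c3cccc(NC(=O)Nc4ccc(Cl)c(Cl)c4)c3)cc2-c2ccncc2)c1` has not yet been measured. It differs from compound 2 by (3,4-dichlorophenyl)amino in place of 3-(trifluoromethyl)phenyl on a carbonyl carbon. This change undoes the kind of change seen in the measured step: the carbonyl carbon again carries an amino-bearing group, as in compound 1, and the (3,4-dichlorophenyl)amino group that enters resembles the (4-chloro-3-(trifluoromethyl)phenyl)amino group of compound 1. Because compound 1 gives 9.1%, a large fall beyond the scatter is expected from compound 2 to compound 3, of about a number 30.7 percentage points lower from compound 2 to compound 3 (beyond the scatter). Compound 3 is therefore estimated at 13%, with a likely range from 4% to 30%.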

Compound 3, a percentage reported as activity, at one concentration (the size of the read-out at that concentration, not a potency): 14.4%
Compound 3: middle estimate off by 1.4 percentage points, on the low side, within the range that was stated.
By their numbers in this assay, from the lowest: compounds 1 and 3 (each within the scatter of the next); then compound 2.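

In this assay, within the data shown here, a second compound with an aryl amino group on the carbonyl carbon now stands well apart from compound 2, with a number 29.3 percentage points lower from compound 2 to compound 3 (beyond the scatter), so the large gap seen earlier is not tied to the single amino group of compound 1. On that outer ring, chloro can take the place of trifluoromethyl without a readable change, with a number 5.3 percentage points higher from compound 1 to compound 3 (within the scatter). Nothing measured here accounts for either result.

Both steps that leave compound 2 change the groups on the outer ring along with adding the amino nitrogen, so the share of that nitrogen alone remains unresolved. As far as these compounds go, how a methoxy or a nitrile group would read in place of the trifluoromethyl of compound 1 also remains open.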